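From compound 1 to compound 4: acetyl at the ring nitrogen

The source may report more compounds than this note shows. Statements on the series, on what has been measured and on what is new or still open speak of the compounds shown alone.

In a physicochemical assay for solubility, in phosphate buffer, measured as kinetic solubility, with a stated time of 24 h, at pH 7.4 (on this read-out higher numbers stand for higher solubility and lower numbers for lower solubility), compound 1 `CC(C)CN(Cc1ccc(N2CCN(NS(C)(=O)=O)CC2)cc1)S(=O)(=O)Cc1ccccc1` reads <= 1000 nM, which is a limit of the assay and not a number. Compound 3 `CC(C)CN(Cc1ccc(N2CCC(C#N)CC2)cc1)S(=O)(=O)Cc1ccccc1` reads <= 1000 nM, which is also a limit. Going by the values given here, compound 2 `CC(C)CN(Cc1ccc(N2CCN(C)CC2)cc1)S(=O)(=O)Cc1ccccc1` gives 60000 nM, the only true number so far. The series therefore rests largely on (the limit of <= 1000 nM in this assay, at which 2 of the 3 values shown sit).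

Compound 4 `CC(=O)N1CCN(c2ccc(CN(CC(C)C)S(=O)(=O)Cc3ccccc3)cc2)CC1` has acetyl in place of methanesulfonamido on an amine nitrogen in a ring, the same place that changes in compound 2: acetyl in place of methanesulfonamido on an amine nitrogen in a ring.

Among the compounds with values here, three measured steps bear on this change. The methyl exchange at this place gives an at least 60-fold higher number from compound 1 to compound 2 (1.77 log units; beyond the scatter), which is large. The step of an at least 60-fold lower number from compound 2 to compound 3 (1.77 log units; beyond the scatter) is equally large, in the opposite direction. The step that the two limits leave unreadable from compound 1 to compound 3 cannot be sized. Within the data shown here, only compound 2 stands clear of the limit, and no acetyl compound has been measured yet, so the large methyl step is not carried over to compound 4. Among the measured compounds shown here, compound 4 is expected to sit with compound 1 and compound 3, with no step clearly beyond the scatter. The expected change is a number no lower from compound 1 to compound 4 (the limit leaves the size open).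

Compound 4 is estimated at 1000 nM, with an expected range of 300 nM to 4000 nM.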

Compound 4, solubility: <= 1000 nM
Compound 4 was reported as a limit; the forecaster's own chance of this, stated with the estimate: 65%; the middle value sits exactly at the limit.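

In this assay compound 4 gives <= 1000 nM, which is a limit of the assay and not a number. The one readable step is an at least 60-fold lower number from compound 2 to compound 4 (1.77 log units; beyond the scatter), so acetyl, like methanesulfonamido in compound 1, does not keep the reading that methyl gives on this amine nitrogen in a ring, and among the three groups shown at this place only methyl, in compound 2, stands clear of the limit. The steps from compound 1 and from compound 3 to compound 4 cannot be read, because each of these pairs has both ends at the same limit: the limit of <= 1000 nM in this assay, at which 3 of the 4 values shown sit.

Going by these compounds, how far compound 1, compound 3 and compound 4 lie apart stays open, as all three rest on that limit. Also open, on these data alone, is whether the reading of compound 2 belongs to methyl alone or returns with ethyl or 2-hydroxyethyl on the same ring nitrogen.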